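The source may report more compounds than this note shows. Statements on the series, on what has been measured and on what is new or still open speak of the compounds shown alone.

Measured so far:
- compound 1 `CCN(CC)CCCn1c(=O)/c(=C/c2cc(OC)c(OC)c(OC)c2)s/c1=C1/C(=O)Nc2ccc(C)cc21`: 2020 nM
- compound 2 `CCN(CC)CCCn1c(=O)/c(=C/c2ccc(F)cc2F)s/c1=C1/C(=O)Nc2cc(F)ccc21`: 4120 nM

Both values come from a functional assay on K562/Adr cells (Homo sapiens) for cytotoxicity, read by sulforhodamine B assay, with a stated time of 48 h; a lower number here means a stronger inhibitor, a higher number a weaker inhibitor. Of the two numbers, compound 2 has the higher at 4120 nM, and the gap to compound 1 at 2020 nM lies beyond the scatter. The next compound is compound 3 `CCN(CC)CCCn1c(=O)/c(=C/c2ccc(F)cc2F)s/c1=C1\C(=O)Nc2cc(F)ccc21`, and the comparison with compound 2 is the two compounds have the same atoms and bonds and differ only in configuration as drawn: 1 of 2 stereo elements differ; a double bond is drawn E in compound 2 and Z in compound 3. Thus a double bond is drawn E in compound 2 and Z in compound 3.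

Going by the values given here, the series holds no measured pair that differs only in this way, so the size of the step cannot be read from the data. No shift beyond the scatter is expected in this assay, in either direction, though the uncertainty is wide. The expected change is a 1.1-fold lower number from compound 2 to compound 3 (0.04 log units; within the scatter). Compound 3 is estimated at 3800 nM, with an expected range of 1700 nM to 8500 nM.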

Compound 3, half-maximal inhibitory concentration: 4120 nM
Compound 3: the middle estimate sits 1.1-fold (0.04 log units) below what was measured; the measured number falls inside the stated range.
By their numbers in this assay, from the lowest: compound 1; then compounds 2 and 3 (each within the scatter of the next).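

In this assay, the drawn configuration of one double bond gives no change at the digits printed from compound 2 to compound 3 (within the scatter). Going by these compounds alone, this is the first step that can be read in one place, whereas compound 1 and compound 2 differ in more than one place, and it isolates a single variable: the fact that compounds 2 and 3 differ only in the configuration as drawn. Within the data shown here, for this pair, with the second stereo element drawn the same in both compounds, the number does not separate the E and Z drawings, a finding that extends to no other compound.

The compounds shown leave open whether the same holds with the other substituents of compound 1, which carries three methoxy groups. They also leave open whether it holds when the diethylamine at the end of the side chain gives way to a morpholine, or the chain to a longer one.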